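Adding a hydroxy to the benzyl group of compound 1

The source may report more compounds than this note shows. Statements on the series, on what has been measured and on what is new or still open speak of the compounds shown alone.

Measured in a functional assay on HCT-116 cells (Homo sapiens) for inhibition, read by CCK-8 assay, with a stated time of 48 h; a lower number here means a stronger inhibitor, a higher number a weaker inhibitor:
compound 1 `CCN1CCN(C(=S)SCC(=O)N(Cc2ccc(OC)cc2)c2cc(OC)c(OC)c(OC)c2)CC1`: 7700 nM
compound 2 `COc1ccc(CN(C(=O)CSC(=S)N2CCCc3cc(C)ccc32)c2cc(OC)c(OC)c(OC)c2)cc1`: 5230 nM
compound 3 `COc1ccc(CN(C(=O)CSC(=S)N2CCCc3cc(OC)ccc32)c2cc(OC)c(OC)c(OC)c2)cc1`: > 20000 nM (a limit of the assay, not a number)

Going by the values given here, only two numerical values exist in this set, and the one nearest the starting point is reached by a 1.5-fold lower number from compound 1 to compound 2 (0.17 log units; within the scatter). The next candidate is compound 4 `CCN1CCN(C(=S)SCC(=O)N(Cc2ccc(OC)c(O)c2)c2cc(OC)c(OC)c(OC)c2)CC1`, which differs from the starting compound by hydroxy in place of hydrogen on an aromatic carbon, turning 4-methoxybenzyl into 3-hydroxy-4-methoxybenzyl.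

Among the compounds with values here, no measured step touches that group. All three steps change the group on the thiocarbonyl carbon, so they bear on this change only indirectly. One of them, an at least 3.8-fold higher number from compound 2 to compound 3 (0.58 log units; beyond the scatter), shows that a single change on an aromatic carbon can move the number beyond the scatter, though its size rests on a limit. Going by these compounds, the direction for the new hydroxy remains open, so only a small step is expected, with a wide margin on both sides. The expected change is a 1.9-fold lower number from compound 1 to compound 4 (0.28 log units; within the scatter). The estimate for compound 4 is 4000 nM, with an expected range of 800 nM to 16000 nM.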

Compound 4, half-maximal inhibitory concentration: 530 nM
Beside the measured number, compound 4's estimate is 7.5-fold (0.88 log units) above it; measured number below the stated range.
By their numbers in this assay, from the lowest: compound 4; then compounds 2 and 1 (each within the scatter of the next). At a limit, above all of these: compound 3.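

In this assay, the 4-methoxybenzyl group proves to be a sensitive place in the series: a 15-fold lower number from compound 1 to compound 4 (1.16 log units; beyond the scatter). The earlier steps shown here all changed the group on the thiocarbonyl carbon, and none of them gave a lower number beyond the scatter, whereas a single hydroxy on an aromatic carbon, ortho to a methoxy group, does so here. The values at hand give no measured basis for explaining this step.

Going by these compounds, whether an amino group or a second methoxy on this same carbon would give a similar step remains open. Also open, on these data alone, is whether the 3-hydroxy-4-methoxybenzyl group would have a comparable effect alongside 6-methyl-1,2,3,4-tetrahydroquinolin-1-yl, since it is seen here only with 4-ethylpiperazin-1-yl on the thiocarbonyl carbon.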